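Trifluoromethoxy for cyano carried onto a second core

The compounds below may be only part of what the source reports. "The series", "measured", "known", "first", "only" and "open" are said of these compounds alone.

Measured in a functional assay on MDA-MB-231 cells (Homo sapiens) for inhibition, read by sulforhodamine B assay, tested at 10 uM; a higher number here means more inhibition at the concentration tested (going by the name of the read-out), a lower number less inhibition:
compound 1 `CN1CCN(c2ccc(C3=NN(S(=O)(=O)c4ccc(C#N)cc4)C(c4ccc(N(C)C)cc4)C3)cc2)CC1` gives 99.8%
compound 2 `CN1CCN(c2ccc(C3=NN(S(=O)(=O)c4ccc(OC(F)(F)F)cc4)C(c4ccc(N(C)C)cc4)C3)cc2)CC1` gives 10.6%
compound 3 `CN(C)c1ccc(C2CC(c3ccc(-n4cncn4)cc3)=NN2S(=O)(=O)c2ccc(C#N)cc2)cc1` gives 32.8%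

Compound 1 and compound 2 share one core; compound 3 and compound 4 `CN(C)c1ccc(C2CC(c3ccc(-n4cncn4)cc3)=NN2S(=O)(=O)c2ccc(OC(F)(F)F)cc2)cc1` share another. The two cores differ by 1H-1,2,4-triazol-1-yl in place of 4-methylpiperazin-1-yl on an aromatic carbon, a change that made the step of a number 67 percentage points lower from compound 1 to compound 3 (beyond the scatter). From compound 1 to compound 2 the change trifluoromethoxy in place of cyano on an aromatic carbon gave a number 89.2 percentage points lower from compound 1 to compound 2 (beyond the scatter). The same change, (trifluoromethoxy in place of cyano on an aromatic carbon), now carries compound 3 to compound 4, with the place described in identical words in both cases. Compound 3 already stands at 32.8%, so little room remains downward. The expected step is therefore a number 26.8 percentage points lower from compound 3 to compound 4 (beyond the scatter), smaller than the earlier one. Compound 4 is estimated at 6% in this assay, with a range from 0% to 25%.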

Compound 4, a percentage reported as inhibition, at one concentration (the size of the read-out at that concentration, not a potency): 18.5%
Compound 4: the middle estimate sits 12.5 percentage points below what was measured; the measured number falls inside the stated range.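

In this assay, trifluoromethoxy in place of cyano lowers the number on both cores, giving a number 14.3 percentage points lower from compound 3 to compound 4 (beyond the scatter), but the size of the step does not carry from one core to the other: the same change on two cores in this assay, a number 89.2 percentage points lower (beyond the scatter) from compound 1 to compound 2 and a number 14.3 percentage points lower (beyond the scatter) from compound 3 to compound 4, 74.9 percentage points apart, beyond the scatter of two such steps. With trifluoromethoxy present, 1H-1,2,4-triazol-1-yl in place of 4-methylpiperazin-1-yl gives a number 7.9 percentage points higher from compound 2 to compound 4 (within the scatter), so the large step seen with cyano does not recur: the same change on two cores in this assay, a number 67 percentage points lower (beyond the scatter) from compound 1 to compound 3 and a number 7.9 percentage points higher (within the scatter) from compound 2 to compound 4, 74.9 percentage points apart, beyond the scatter of two such steps. The two changes are therefore not independent across these compounds, although four compounds tested at one concentration do not show why, nor do they give a potency.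

From the compounds shown here alone, it remains open whether a carboxylic acid in place of cyano would follow the larger step or the smaller one. Also open, going by these compounds, is how a morpholine in place of 4-methylpiperazin-1-yl would behave with either group.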